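Compound 1 to compound 4: a chain exchange in the series

A few compounds are considered here, and "the series" means these few. Any claim that something is new, unique, unknown or untested is made for them only; others in the source may bear on it.

In an ADME assay on cells (Homo sapiens) for cytotoxicity, read by resazurin assay, with a stated time of 5 days (a higher number here means that more compound is tolerated, a lower number that less compound is tolerated), compound 1 (`COc1ccc(-c2nc(CCc3cccc(Cl)c3)nc3ccsc23)cn1`) stands at > 50000 nM as a limit of the assay, not a number. Compound 4 (`COc1ccc(-c2nc(CSc3cccc(Cl)c3)nc3ccsc23)cn1`) has not yet been measured. It carries (3-chlorophenyl)sulfanyl in place of 3-chlorobenzyl on a saturated chain carbon bound to an aromatic carbon. Among the compounds with values here, no measured step covers this exchange. The nearest evidence comes from compound 2 (`O=S(=O)(Cc1nc(-c2ccnc(Cl)c2)c2sccc2n1)c1cccc(Cl)c1`) at 63000 nM and compound 3 (`O=S(=O)(Cc1nc(-c2ccc(F)nc2)c2sccc2n1)c1cccc(Cl)c1`) at 40000 nM in the same read-out. Within the data shown here, with a 1.6-fold lower number from compound 2 to compound 3 (0.20 log units; within the scatter) as the only measured step, and at a different place from this exchange, no step beyond the scatter is expected in this assay in either direction. The expected change is an at least 1.1-fold lower number from compound 1 to compound 4 (0.04 log units; that floor lies within the scatter) and carries wide uncertainty, since compound 1 offers only a limit as its starting point. For compound 4 the estimated value is 45000 nM, with an expected range from 20000 nM to 80000 nM and a fair chance of another reading at the limit.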

Compound 4, half-maximal cytotoxic concentration: > 10000 nM
Compound 4: only a limit was reported; the forecaster's own chance of this, stated with the estimate: 40%; the middle value is on the limit's open side.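

No step can be read between compound 1 and compound 4: in this assay each stands only as a limit of the assay. Whether (3-chlorophenyl)sulfanyl in place of 3-chlorobenzyl changes the tolerated concentration, and in which direction, stays open in the compounds shown.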